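Working notes: 4-bromophenyl to 3,4-dichlorophenyl

The source may report more compounds than this note shows. Statements on the series, on what has been measured and on what is new or still open speak of the compounds shown alone.

Within the data shown here, in a functional assay on A549 cells (Homo sapiens) for antiproliferative activity, read by MTT assay (a higher number here means a weaker inhibitor, a lower number a stronger inhibitor), compound 1 `O=[N+]([O-])c1ccc(Nc2nccc(-c3ccc(Br)cc3)n2)cc1` gives 76000 nM, the higher of the two numbers so far. Compound 2 `COc1ccc(-c2ccnc(Nc3cccc(OC)c3)n2)cc1` gives 6530 nM, and this gap lies beyond the scatter. Compound 3 `O=[N+]([O-])c1ccc(Nc2nccc(-c3ccc(Cl)c(Cl)c3)n2)cc1` carries 3,4-dichlorophenyl in place of 4-bromophenyl on an aromatic carbon. Among the measured compounds shown here, no measured pair isolates this change, so the expectation remains loose. The estimated step is a 1.9-fold lower number from compound 1 to compound 3 (0.28 log units; within the scatter), expected toward a stronger inhibitor but not beyond the scatter. In this assay, the estimate for compound 3 is 40000 nM, with an expected range of 12000 nM to 100000 nM.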

Compound 3, half-maximal inhibitory concentration: 720 nM
Beside the measured number, compound 3's estimate is 56-fold (1.74 log units) above it; measured number outside the range, below it.
By their numbers in this assay, from the lowest: compound 3; then compound 2; then compound 1.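

In this assay, among these compounds, 3,4-dichlorophenyl in place of 4-bromophenyl gives a 110-fold lower number from compound 1 to compound 3 (2.02 log units; beyond the scatter) and shows that this position, next to the ring nitrogen, responds strongly to the aryl substituents, which no earlier pair could show. The step exchanges one bromine for two chlorine atoms, so it does not separate halogen identity from halogen count or placement. Nothing available accounts for the size of this step.

A 4-chlorophenyl or 3-chlorophenyl group would separate these factors. Going by these compounds, how an amine or a carboxylic acid on this phenyl ring would read remains open.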